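Solubility in the series: shrinking the chain on the core

A few compounds are considered here, and "the series" means these few. Any claim that something is new, unique, unknown or untested is made for them only; others in the source may bear on it.

Measured compounds:
compound 1 `CCCCCCCc1c(C)[nH]c2cc(OC)c(Cl)cc2c1=O` — < 2000 nM
compound 2 `COc1cc2[nH]c(C)c(C3CCCCC3)c(=O)c2cc1Cl` — 5000 nM
compound 3 `COc1cc2[nH]c(C)c(C)c(=O)c2cc1Cl` — not yet measured

Among the compounds with values here, in a physicochemical assay for solubility, read by HPLC, at pH 7.4 (a lower number here means a less soluble compound, a higher number a more soluble compound), compound 2 gives 5000 nM, which is the only number in the set so far. For compound 1 the value < 2000 nM is a limit of the assay and not a number (the limit of < 2000 nM in this assay, at which 1 of the 2 values shown sits). Within the data shown here, the one measured step, an at least 2.5-fold higher number from compound 1 to compound 2 (0.39 log units; beyond the scatter), is the only evidence that bears on compound 3, which differs from compound 2 by methyl in place of cyclohexyl on an aromatic carbon; both changes reduce the group on the same aromatic carbon of the shared core. A further rise beyond the scatter is therefore expected for compound 3, with a step of a 4.0-fold higher number from compound 2 to compound 3 (0.60 log units; beyond the scatter) from compound 2. The estimate for compound 3 in this assay is 20000 nM, with a range of 6000 nM to 70000 nM.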

Compound 3, solubility: 5000 nM
Estimate against measurement, compound 3: 4.0-fold (0.60 log units) above; measured number below the stated range.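

In this assay, methyl in place of cyclohexyl on this aromatic carbon gives no change at the digits printed from compound 2 to compound 3 (within the scatter), so removing the six-membered carbon ring leaves the reading where it stood. Among the three compounds, only the steps away from heptyl exceed the scatter, including an at least 2.5-fold higher number from compound 1 to compound 3 (0.39 log units; beyond the scatter), so the rise seen on leaving heptyl does not continue as the group shrinks further from cyclohexyl to methyl. The reading for compound 1 is a limit of the assay and not a number: the limit of < 2000 nM in this assay, at which 1 of the 3 values shown sits.

Going by these compounds, the true size of the steps away from heptyl therefore remains open, as does the point between heptyl and cyclohexyl at which the reading shifts. Also open, on these data alone, is whether an amine or a carboxylic acid on this aromatic carbon would move the reading away from those of compound 2 and compound 3.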